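Swapping Methoxy for Ethyl on the Pyrimidine Ring

The source may report more compounds than this note shows. Statements on the series, on what has been measured and on what is new or still open speak of the compounds shown alone.

In a functional assay on CHO-K1 cells for antagonist activity at C-X-C chemokine receptor type 3 (Homo sapiens), read by FLIPR, with a stated time of 10 min (a lower number here means a stronger inhibitor, a higher number a weaker inhibitor), three compounds have been measured:

Compound 1 `COc1ncc(-c2nc(C(F)(F)F)sc2N2CCN(C(=O)Cn3cnc4cccnc43)[C@H](C)C2)cn1`: 3.8 nM
Compound 2 `CCOc1ncc(-c2nc(C(F)(F)F)sc2N2CCN(C(=O)Cn3ccc4cccnc43)[C@H](C)C2)cn1`: 3.8 nM
Compound 3 `COc1ncc(-c2nc(C(F)(F)F)sc2N2CCN(C(=O)Cn3nc(C)nc3C)[C@H](C)C2)cn1`: 25 nM

Compound 3 stands highest of the three numbers, which in this assay means it is the weakest inhibitor shown. For the measured compounds named here, the only single-point step recorded, a 6.6-fold higher number from compound 1 to compound 3 (0.82 log units; beyond the scatter), concerns the group on the saturated chain carbon bound to the carbonyl carbon, not the pyrimidine ring. Compound 1 and compound 2 give the same number, but they differ in two places at once, so their pair says nothing on its own about any one change.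

Compound 4 `CCc1ncc(-c2nc(C(F)(F)F)sc2N2CCN(C(=O)Cn3nc(C)nc3C)[C@H](C)C2)cn1` differs from compound 3 by ethyl in place of methoxy on an aromatic carbon. Going by the values given here, no measured step touches this position, so there is no direct guide. In the absence of such evidence the step of a 1.2-fold higher number from compound 3 to compound 4 (0.08 log units; within the scatter) is expected to stay within the usual scatter, in either direction. Compound 4 is therefore estimated at 30 nM in this assay, with a range from 10 nM to 100 nM.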

Compound 4, half-maximal inhibitory concentration: 14 nM
Estimate against measurement, compound 4: 2.1-fold (0.33 log units) above, and the stated range covers the measured number.
By their numbers in this assay, from the lowest: compounds 1 and 2 (each within the scatter of the next); then compounds 4 and 3 (each within the scatter of the next).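

In this assay the change from 2-methoxypyrimidin-5-yl to 2-ethylpyrimidin-5-yl gives a 1.8-fold lower number from compound 3 to compound 4 (0.25 log units; within the scatter) and so leaves the two compounds indistinguishable. For the compounds shown here, this is the first measured step at this place, and it shows that, in this pair, the methoxy group with its hydrogen-bond acceptor can give way to an ethyl group with none, with no step beyond the scatter. No measurement shown here accounts for this result.

On these data alone, whether the same swap would hold when the chain carbon carries the larger group of compound 1 remains open, since this single pair covers only the group shared by compound 3 and compound 4. Also open, as far as these compounds go, is how a longer chain such as propyl, or an amine, would fare at this place.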